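Carbonyl substituent swap on the shared core

The source may report more compounds than this note shows. Statements on the series, on what has been measured and on what is new or still open speak of the compounds shown alone.

The two measured compounds share a common core and differ only in the group attached to the carbonyl carbon of the ring amide. Compound 1 `Cc1nc(S(C)(=O)=O)ccc1Oc1ncnc(OC2CCN(C(=O)OC(C)(C)C(F)(F)F)CC2)c1F` gives 6.53 nM in a functional assay on isolated protein for inhibition of Glucose-dependent insulinotropic receptor (Homo sapiens), read by HTRF and cAMP accumulation; a higher number here means that more compound is needed for the effect, a lower number that less compound is needed. Compound 2 `Cc1nc(S(C)(=O)=O)ccc1Oc1ncnc(OC2CCN(C(=O)SC3(C)CC3)CC2)c1F` gives 13.2 nM in this assay; of the two numbers it is the higher one, and its nearest neighbour is compound 1, with a 2.0-fold higher number from compound 1 to compound 2 (0.31 log units; beyond the scatter). The unmeasured compound 3 `CCC(F)(F)C(=O)N1CCC(Oc2ncnc(Oc3ccc(S(C)(=O)=O)nc3C)c2F)CC1` differs from compound 2 by a group of 5 heavy atoms (3 carbon, 2 fluorine; no ring) in place of a group of 5 heavy atoms (4 carbon, 1 sulfur; one three-membered non-aromatic ring of carbon only), on a carbonyl carbon. Within the data shown here, the only step that bears on this position is the one from compound 1 to compound 2, and it was modest, so another modest shift is the most that the data support; the group entering compound 3 carries fluorine, as did the group in compound 1. Compound 3 is expected to give 8 nM in this assay, within 3 nM to 25 nM. This corresponds to an expected step of a 1.7-fold lower number from compound 2 to compound 3 (0.22 log units; within the scatter).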

Compound 3, half-maximal effective concentration: 17.4 nM
Beside the measured number, compound 3's estimate is 2.2-fold (0.34 log units) below it, and the stated range covers the measured number.
By their numbers in this assay, from the lowest: compound 1; then compounds 2 and 3 (each within the scatter of the next).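

Swapping the sulfur-linked ring group for 1,1-difluoropropyl on the carbonyl carbon leaves the reading in this assay essentially unmoved, with a 1.3-fold higher number from compound 2 to compound 3 (0.12 log units; within the scatter). At this position, then, a group with no ring and no sulfur serves as well as the one it replaces, at least among these two compounds. Fluorine in the group does not by itself match compound 1, since both groups carry it and yet the comparison gives a 2.7-fold higher number from compound 1 to compound 3 (0.43 log units; beyond the scatter).

The compounds shown leave open how a plain propyl chain without fluorine, or a cyclopropyl group, would read on the same carbonyl carbon. They also leave open whether the 1-methyl-1-(trifluoromethyl)ethoxy group owes its lower number to its oxygen link or to its trifluoromethyl group. No supporting measurement is available to explain any of these numbers.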